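Antiproliferative series: pentafluorosulfanyl anilides with trifluoromethyl additions

The compounds below may be only part of what the source reports. "The series", "measured", "known", "first", "only" and "open" are said of these compounds alone.

Compound 1 `CC(O)(CSc1cccc(C(F)(F)F)c1)C(=O)Nc1cccc(S(F)(F)(F)(F)F)c1` is the reference of the first pair. In a functional assay on LNCaP cells (Homo sapiens) for antiproliferative activity, read by propidium iodide staining, with a stated time of 96 h (on this read-out higher numbers stand for weaker inhibition and lower numbers for stronger inhibition), compound 1 gives 12700 nM. Compound 2 `CC(O)(CSc1cc(C(F)(F)F)cc(C(F)(F)F)c1)C(=O)Nc1cccc(S(F)(F)(F)(F)F)c1` carries the change trifluoromethyl in place of hydrogen on an aromatic carbon relative to compound 1, and in this assay compound 2 gives 4800 nM. Among the compounds with values here, the step of a 2.6-fold lower number from compound 1 to compound 2 (0.42 log units; beyond the scatter) is the only measured step in the set.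

Compound 3 `CC(O)(COc1cccc(C(F)(F)F)c1)C(=O)Nc1ccc(S(F)(F)(F)(F)F)cc1` has a different core; the difference between the core of compound 1 and the core of compound 3 is not broken down here. In this assay compound 3 gives 24700 nM, the highest number among the three measured compounds, though compound 1 sits within the scatter of it and only compound 2 lies clearly lower.

Compound 4 `CC(O)(COc1cc(C(F)(F)F)cc(C(F)(F)F)c1)C(=O)Nc1ccc(S(F)(F)(F)(F)F)cc1` is not yet measured. Its change relative to compound 3 is trifluoromethyl in place of hydrogen on an aromatic carbon, the same change as that from compound 1 to compound 2, at the same kind of place. Within the data shown here, for compound 4 a step of a 2.6-fold lower number from compound 3 to compound 4 (0.41 log units; beyond the scatter) is expected in this assay, resting on the single measured step of a 2.6-fold lower number from compound 1 to compound 2 (0.42 log units; beyond the scatter) as the only guide. Compound 4 is therefore estimated at 9500 nM, with a range from 4000 nM to 24000 nM.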

Compound 4, half-maximal inhibitory concentration: 2300 nM
Beside the measured number, compound 4's estimate is 4.1-fold (0.62 log units) above it; the whole stated range lies above it.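

In this assay trifluoromethyl in place of hydrogen on an aromatic carbon lowers the number on the core of compound 3 as it does on the core of compound 1, here giving an 11-fold lower number from compound 3 to compound 4 (1.03 log units; beyond the scatter). The direction of the change carries from one core to the other in these two pairs, but its size does not: the same change on two cores in this assay, a 2.6-fold lower number (0.42 log units; beyond the scatter) from compound 1 to compound 2 and an 11-fold lower number (1.03 log units; beyond the scatter) from compound 3 to compound 4, 4.1-fold (0.61 log units) apart, beyond the scatter of two such steps. The core of compound 1 and the core of compound 3 differ in more than one place, so these two pairs cannot tell which of those differences goes with the larger step, and two pairs give no rule for a further core.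

Still open, from the compounds shown here alone, is whether a third core would give a step nearer the smaller or the larger of these two. Also open, going by these compounds, is whether a nitrile, a chlorine atom or an amine on the same aromatic carbon would follow trifluoromethyl in direction and in size on both cores.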